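The source may hold more compounds than are shown below. What is called first, only, known or untested is meant among the compounds shown, and "the series" means these compounds.

Compound 3, with the structure `CCCCNS(=O)(=O)c1ccc(Nc2ncc3c(n2)N(c2ccn(C)n2)C(CC)C(=O)N3C)cc1`, stands highest among the three measured compounds in a functional assay on A549 cells (Homo sapiens) for antiproliferative activity, read by CCK-8 assay, with a stated time of 72 h (on this read-out lower numbers stand for stronger inhibition of growth and higher numbers for weaker inhibition of growth), where compound 3 gives 10600 nM. Compound 2, with the structure `CC[C@@H]1C(=O)N(C)c2cnc(Nc3ccc(S(=O)(=O)NC4CCCC4)cc3)nc2N1C1CCCC1`, gives 1150 nM in this assay, and compound 1, with the structure `CCCNS(=O)(=O)c1ccc(Nc2ncc3c(n2)N(C2CCCC2)[C@H](CC)C(=O)N3C)cc1`, gives 563 nM. The unmeasured compound 4 has the structure `CCC1C(=O)N(C)c2cnc(Nc3ccc(S(=O)(=O)NC)cc3)nc2N1c1ccn(C)n1`; it differs from compound 3 by hydrogen in place of propyl on a saturated chain carbon bound to a sulfonamide nitrogen. For the measured compounds named here, the only measured step that bears on this kind of change is a 2.0-fold higher number from compound 1 to compound 2 (0.31 log units; beyond the scatter), in which a larger group on the sulfonamide nitrogen went with a higher number; that step, however, was read on a different core than the one shared by compound 3 and compound 4, and it moved in the opposite direction, toward a bulkier group. A shorter group is therefore expected to give a modest step toward a lower number in this assay, of about a 1.4-fold lower number from compound 3 to compound 4 (0.15 log units; within the scatter), though much of that would sit near the usual scatter. Compound 4 is estimated to give 7500 nM in this assay, with a range from 2500 nM to 22000 nM.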

Compound 4, concentration for 50% growth inhibition: 12600 nM
Beside the measured number, compound 4's estimate is 1.7-fold (0.23 log units) below it, and the stated range covers the measured number.
By their numbers in this assay, from the lowest: compound 1; then compound 2; then compounds 3 and 4 (each within the scatter of the next).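

In this assay, going from butylsulfamoyl to methylsulfamoyl on the shared core gives a 1.2-fold higher number from compound 3 to compound 4 (0.08 log units; within the scatter), so on this core the two chain lengths cannot be told apart. The earlier step, a 2.0-fold higher number from compound 1 to compound 2 (0.31 log units; beyond the scatter), was beyond the scatter, but it exchanged propyl for cyclopentyl on a different core; the new pair shows that removing propyl from the saturated chain carbon bound to a sulfonamide nitrogen leaves the number within the scatter here. No measured evidence offers an explanation for this result.

Still open, going by these compounds, is whether a ring such as cyclopentyl, a longer chain such as octyl, or a chain ending in an amine or a carboxylic acid would also leave the number within the scatter on this core. Compound 3 differs from compound 1 in more than one place, so the shown pairs cannot separate the contribution of the rest of the core.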